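The compounds below may be only part of what the source reports. "The series", "measured", "known", "first", "only" and "open" are said of these compounds alone.

Working notes on the series.

Compound 1 `COc1ccc(-c2c(C)[nH]c(=O)n2C)cc1` carries a methoxy on the aryl ring and gives 147000 nM in a functional assay on brain (Rattus norvegicus, strain Wistar) for inhibition; on this read-out lower numbers stand for stronger inhibition and higher numbers for weaker inhibition. Compound 2 `CCCCCOc1ccc(-c2c(C)[nH]c(=O)n2C)cc1` differs from it by butyl in place of hydrogen on a saturated chain carbon bound to an oxygen on an aromatic ring and gives 4500 nM in this assay, a step of a 33-fold lower number from compound 1 to compound 2 (1.51 log units; beyond the scatter).

Compound 3 `CCCCCCCCCCCCCCc1ccc(-c2c(C)[nH]c(=O)n2C2CCCCC2)cc1` has a core that differs from that of compound 1; the difference between the two cores is not broken down here. In this assay compound 3 gives > 100000 nM, which is a limit of the assay and not a number, sitting at the limit of > 100000 nM in this assay, at which 1 of the 3 values shown sits.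

Compound 4 `CCCCCCCCCCCCCCCCCCc1ccc(-c2c(C)[nH]c(=O)n2C2CCCCC2)cc1` is not yet measured. It differs from compound 3 by butyl in place of hydrogen on a saturated chain carbon, ten or more bonds along the chain from an aromatic carbon. This is the same kind of change as from compound 1 to compound 2, but the place is not the same: there the butyl enters on a saturated chain carbon bound to an oxygen on an aromatic ring, here on a saturated chain carbon many bonds along the chain from an aromatic carbon. Because compound 3 gives only the limit > 100000 nM, no numbered starting point exists for this step, and the step from compound 1 to compound 2 rests on a different place and core. The step from compound 3 to compound 4 is expected to be a step that the limit leaves unreadable from compound 3 to compound 4, carrying little weight. Compound 4 is estimated at 150000 nM in this assay, between 30000 nM and 1000000 nM, most likely reported again only as a limit.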

Compound 4, half-maximal inhibitory concentration: > 100000 nM
Compound 4: no number, only a limit (the forecaster's own chance of this, stated with the estimate: 75%); the middle value is on the limit's open side.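

In this assay compound 4 gives > 100000 nM, a limit and not a number. Compound 3 also stands only as a limit, so no step can be read between compound 3 and compound 4: the limit of > 100000 nM in this assay, at which 2 of the 4 values shown sit.

The compounds shown leave open whether any chain on the core of compound 3 gives a numbered value in this assay.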